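Ring-opening of the aminocyclopropyl group in compound 4

This account rests on a few compounds, and the source may have more. Where it says the series, first, only, none or still open, it means among the compounds named here.

Compound 1 `C[C@@H]1SCc2ncnc(N3CCN(C(=O)C(Cc4ccc(Cl)cc4)C4(N)CC4)CC3)c21`: 2470 nM
Compound 2 `CC(C)NCC(Cc1ccc(Cl)c(F)c1)C(=O)N1CCN(c2ncnc3c2[C@H](C)SC3)CC1`: 92 nM
Compound 3 `C[C@@H]1SCc2ncnc(N3CCN(C(=O)C(Cc4ccc(Cl)c(F)c4)CC4(N)CC4)CC3)c21`: 250 nM

Among the compounds with values here, in an assay on LNCaP cells for inhibition of RAC-alpha serine/threonine-protein kinase (Homo sapiens) (on this read-out lower numbers stand for stronger inhibition and higher numbers for weaker inhibition), compound 3 gives 250 nM, the second highest of the three numbers so far. Its nearest neighbour is compound 2, which gives 92 nM in this assay. The highest number of the set belongs to compound 1, which differs from compound 3 in several places; in this assay compound 1 gives 2470 nM.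

Compound 4 `C[C@@H]1SCc2ncnc(N3CCN(C(=O)C(Cc4ccc(Cl)c(F)c4)CC(C)(C)N)CC3)c21` is the next member. It differs from compound 3 by 1-amino-1-methylethyl in place of 1-aminocyclopropyl on a saturated chain carbon, two bonds along the chain from a carbonyl carbon. Within the data shown here, the only measured step touching this part of the molecule is a 2.7-fold higher number from compound 2 to compound 3 (0.43 log units; beyond the scatter). That step exchanged an amine of one shape for another at the same position and moved the number only modestly, so the present exchange, which keeps the amine and its substitution pattern and merely opens the three-membered ring into two methyl groups, is expected to be smaller still. Compound 4 is therefore expected to give 250 nM in this assay, somewhere between 90 nM and 700 nM, which amounts to an expected step of no change at the digits printed from compound 3 to compound 4 (within the scatter), within the scatter of this assay.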

Compound 4, half-maximal inhibitory concentration: 587 nM
Compound 4: the middle estimate sits 2.3-fold (0.37 log units) below what was measured, and the stated range covers the measured number.
By their numbers in this assay, from the lowest: compound 2; then compound 3; then compound 4; then compound 1.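

Opening the three-membered ring into 1-amino-1-methylethyl gave, in this assay, a 2.3-fold higher number from compound 3 to compound 4 (0.37 log units; beyond the scatter), a step beyond the scatter even though the two groups have the same counts of heavy atoms, hydrogen-bond donors and hydrogen-bond acceptors, so this position responds to the presence of the ring itself and not only to those counts. Measured against the isopropylamino group, the same 1-amino-1-methylethyl group gave a 6.4-fold higher number from compound 2 to compound 4 (0.80 log units; beyond the scatter), which places the three groups in a clear order on this side chain, with isopropylamino giving the lowest number, 1-aminocyclopropyl the next and 1-amino-1-methylethyl the highest. No measurement at hand explains why the closed ring and the two methyl groups part in this way.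

The compounds shown leave open whether a larger ring, such as 1-aminocyclobutyl, would stay nearer the cyclopropyl or the open-chain result. They also leave open whether a 1-aminoethyl group, with one methyl group in place of two, would recover any of the difference, and whether the order of these groups would hold on a different aryl group.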